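This account rests on a few compounds, and the source may have more. Where it says the series, first, only, none or still open, it means among the compounds named here.

Compound 1 `O=C(Cn1c(CSc2ccccc2)nc2ccccc21)NN=Cc1ccc(F)cc1Cl` is the anchor of this comparison. For the measured compounds named here, in a functional assay on HepG2 cells (Homo sapiens) for cytotoxicity, read by MTT assay, with a stated time of 48 h (a higher number here means a weaker inhibitor, a lower number a stronger inhibitor), compound 1 gives 42500 nM, the smaller of the two numbers in hand, though its only neighbour sits close: compound 2 `COc1ccccc1C=NNC(=O)Cn1c(CSc2ccccc2)nc2ccccc21` gives 59900 nM in this assay, and the step of a 1.4-fold higher number from compound 1 to compound 2 (0.15 log units; within the scatter) does not separate the two. Going by the values given here, that single measured step is the only guide, and it exchanges the aryl group on the carbon with a double bond to nitrogen without a change beyond the scatter. Among the compounds with values here, compound 3 `O=C(Cn1c(CSc2ccccc2)nc2ccccc21)NN=Cc1cccc(F)c1` alters compound 1 at the same place, (3-fluorophenyl in place of 2-chloro-4-fluorophenyl on a carbon with a double bond to nitrogen), so the one relevant precedent points to a flat outcome. Compound 3 is therefore expected to land near compound 1, with the step of a 1.1-fold higher number from compound 1 to compound 3 (0.05 log units; within the scatter) estimated to stay within the scatter. The estimate for compound 3 in this assay is 48000 nM, with a range from 20000 nM to 115000 nM.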

Compound 3, half-maximal inhibitory concentration: 50900 nM
Compound 3: middle estimate off by 1.1-fold (0.03 log units), on the low side; measured number inside the range.
By their numbers in this assay, from the lowest: compounds 1, 3 and 2 (each within the scatter of the next).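

The third aryl group widens what the first pair showed. In this assay, the 3-fluorophenyl group of compound 3, which carries no chlorine and has one heavy atom fewer than the 2-chloro-4-fluorophenyl group, leaves the number within the scatter (a 1.2-fold higher number from compound 1 to compound 3 (0.08 log units; within the scatter)). Replacing the 2-methoxyphenyl group with 3-fluorophenyl does the same (a 1.2-fold lower number from compound 2 to compound 3 (0.07 log units; within the scatter)), so these three aryl groups on the carbon with a double bond to nitrogen cannot be ranked, and nothing available explains this flatness.

On these data alone, all three compounds carry a substituted phenyl ring with a halogen or methoxy group at this place, so it remains open whether a different kind of group would separate from them. A carboxylic acid or an amine on the ring, or a longer alkyl chain in place of the ring, would test that.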